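The source may report more compounds than this note shows. Statements on the series, on what has been measured and on what is new or still open speak of the compounds shown alone.

The set comprises three measured compounds and a fourth that awaits testing. Compound 1 `O=C(N/N=C/c1ccccc1)Nc1ccc(Oc2ccnc3[nH]ccc23)c(F)c1` carries a fluoro group on an aromatic carbon; in a functional assay on A549 cells (Homo sapiens) for antiproliferative activity, read by MTT assay, with a stated time of 72 h (on this read-out higher numbers stand for weaker inhibition and lower numbers for stronger inhibition), compound 1 gives 2500 nM. Compound 2 `COc1ccc(/C=N/NC(=O)Nc2ccc(Oc3ccnc4[nH]ccc34)c(F)c2)c(OC)c1OC` keeps that fluoro group but differs from compound 1 in several respects; the difference between the two cores is not broken down here. In this assay compound 2 gives 1450 nM, and the values of compound 2 and compound 1 lie within the usual scatter of each other. Compound 3 `O=C(N/N=C/c1ccccc1)Nc1ccc(Oc2ccnc3[nH]ccc23)cc1` is compound 1 after (hydrogen in place of fluoro on an aromatic carbon). In this assay compound 3 gives 17200 nM, so that single change brought a 6.9-fold higher number from compound 1 to compound 3 (0.84 log units; beyond the scatter).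

Compound 4 `COc1ccc(/C=N/NC(=O)Nc2ccc(Oc3ccnc4[nH]ccc34)cc2)c(OC)c1OC` stands to compound 2 as compound 3 stands to compound 1: hydrogen in place of fluoro on an aromatic carbon. The surroundings of the change are described in identical words in both cases, so this is the same change made on a second core. For the measured compounds named here, only that one earlier instance exists, and whether the second core responds alike is not known from these data. The expectation rests on compound 1, whose step to compound 3 was a 6.9-fold higher number from compound 1 to compound 3 (0.84 log units; beyond the scatter). On that basis compound 4 is expected to show a step of a 6.2-fold higher number from compound 2 to compound 4 (0.79 log units; beyond the scatter) in this assay, with some allowance for the core being different. In this assay compound 4 is accordingly estimated at 9000 nM, and its value is expected to lie between 3000 nM and 30000 nM.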

Compound 4, half-maximal inhibitory concentration: 3340 nM
For compound 4 the middle estimate is 2.7-fold (0.43 log units) above the measured one, and the stated range covers the measured number.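

In this assay, replacing the fluoro group with hydrogen on the second core again raised the number, a 2.3-fold higher number from compound 2 to compound 4 (0.36 log units; beyond the scatter), so the direction of the change carried over and both cores lost inhibitory strength on losing the fluoro group. The size of the step did not carry over, and a single step measured on one core would have overstated the loss on the other: the same change on two cores in this assay, a 6.9-fold higher number (0.84 log units; beyond the scatter) from compound 1 to compound 3 and a 2.3-fold higher number (0.36 log units; beyond the scatter) from compound 2 to compound 4, 3.0-fold (0.48 log units) apart, beyond the scatter of two such steps. For the compounds shown here, with only two cores, these data do not show which of the several differences between them sets the size of the step, nor how a third core would respond, so the direction is supported only for this pair and the size cannot be transferred from one core to another.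

The compounds shown leave open what other groups on the same aromatic carbon would do, for instance a chlorine atom, a methyl group or a nitrile in place of the fluoro group. They also leave open how the step would behave on cores bearing other groups in place of the methoxy groups, such as an amine or a carboxylic acid, and whether the pattern holds beyond this one cell line.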